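Dichlorobenzimidazole series: benzylsulfanyl in place of amino

The compounds below may be only part of what the source reports. "The series", "measured", "known", "first", "only" and "open" are said of these compounds alone.

Measured so far:
compound 1 `Nc1nc2cc(Cl)c(Cl)cc2n1COCCO` — > 100000 nM
compound 2 `Nc1nc2c(Cl)cc(Cl)cc2n1COCCO` — > 100000 nM
compound 3 `Nc1nc2c(Cl)c(Cl)ccc2n1COCCO` — > 100000 nM

All three values in a functional assay on KB cells (Homo sapiens) for inhibition (on this read-out lower numbers stand for stronger inhibition and higher numbers for weaker inhibition), are limits of the assay, not numbers. Compound 1 gives only a limit. Compound 2 likewise gives only a limit. Compound 3 sits at the limit of > 100000 nM in this assay, at which 3 of the 3 values shown sit, so nothing places it relative to compound 1 or compound 2 beyond that shared limit.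

Compound 4 `OCCOCn1c(SCc2ccccc2)nc2c(Cl)c(Cl)ccc21` is the next candidate for this assay. Its difference from compound 3: benzylsulfanyl in place of amino on an aromatic carbon. Among the compounds with values here, no measured step bears on this change, and all three measured compounds sit at the limit, so the direction and size of the step are open. Some gain in inhibition is plausible but not supported by any measured step. Compound 4 is expected at 60000 nM (range 8000 nM to 400000 nM), an estimated step of an at least 1.6-fold lower number from compound 3 to compound 4 (0.22 log units; that floor lies within the scatter), with a real chance that only a limit is reported again.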

Compound 4, half-maximal inhibitory concentration: 35000 nM
Beside the measured number, compound 4's estimate is 1.7-fold (0.23 log units) above it; measured number inside the range.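

In this assay, benzylsulfanyl in place of amino on the aromatic carbon between two ring nitrogen atoms gives an at least 2.8-fold lower number from compound 3 to compound 4 (0.45 log units; beyond the scatter). This position therefore accepts a far larger group than amino while inhibition rises, though the step is only a bound. Compound 4 is the only compound shown that gives a number rather than a limit: the limit of > 100000 nM in this assay, at which 3 of the 4 values shown sit.

Going by these compounds, whether the sulfur, the six-membered aromatic ring or the loss of amino carries the step stays open, and methylsulfanyl or benzylamino would help separate these. Also open, on these data alone, is whether benzylsulfanyl gives a similar step on the chlorine patterns of compound 1 and compound 2.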